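The compounds below may be only part of what the source reports. "The series", "measured", "known", "first", "only" and "open" are said of these compounds alone.

Of the compounds shown here, three built on a shared core have been measured in an assay on cells for antagonist activity at transient receptor potential cation channel subfamily V member 1 (Homo sapiens), read by FLIPR and calcium flux, with a stated time of 15 min; on this read-out lower numbers stand for stronger inhibition and higher numbers for weaker inhibition. Compound 1 `CC1CCN(c2nc(C(F)(F)F)ccc2CNC(=O)C(C)c2ccc(NS(C)(=O)=O)c(Cl)c2)CC1` gives 2.3 nM in this assay. Compound 2 `CC1CCN(c2nc(C(F)(F)F)ccc2CNC(=O)C(C)c2cc(F)c(NS(C)(=O)=O)c(Br)c2)CC1` gives 0.7 nM in this assay. Compound 3 `CC1CCN(c2nc(C(F)(F)F)ccc2CNC(=O)C(C)c2ccc(NS(=O)(=O)C(C)C)c(F)c2)CC1` gives 8.7 nM in this assay, the highest of the three numbers; its gaps to compound 1 and to compound 2 both lie beyond the scatter, so compound 3 is the weakest inhibitor of the set.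

Compound 4 `CCN(c1ccc(C(C)C(=O)NCc2ccc(C(F)(F)F)nc2N2CCC(C)CC2)cc1F)S(C)(=O)=O` has not yet been measured in this assay. It differs from compound 3 in a single place: ethyl(methylsulfonyl)amino in place of (isopropylsulfonyl)amino on an aromatic carbon. The two groups hold the same atoms, but the hydrogen-bond donor of the sulfonamide is lost in compound 4. Within the data shown here, no measured pair among the three compounds shows a change of this kind, so there is no step to lean on. The expected step is a 4.6-fold higher number from compound 3 to compound 4 (0.66 log units; beyond the scatter), a move toward weaker inhibition and of a size beyond the scatter. In this assay compound 4 is therefore expected to give 40 nM, within a range from 8 nM to 200 nM.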

Compound 4, inhibition constant: 22.7 nM
Compound 4: middle estimate off by 1.8-fold (0.25 log units), on the high side; the measured number falls inside the stated range.
By their numbers in this assay, from the lowest: compound 2; then compound 1; then compound 3; then compound 4.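

In this assay, rearranging the same atoms from (isopropylsulfonyl)amino to ethyl(methylsulfonyl)amino on this aromatic carbon gives a 2.6-fold higher number from compound 3 to compound 4 (0.42 log units; beyond the scatter), a modest move toward weaker inhibition that lies beyond the scatter. The entering group has 0 hydrogen-bond donors, so this position, ortho to a fluoro group, shows that inhibition is weakened but not abolished when the sulfonamide hydrogen is gone and the carbons are redistributed. Nothing measured here accounts for the size of this step.

The shown compounds do not separate the lost hydrogen from the shift of carbons from sulfur to nitrogen, as both change in the same step. A methyl group on that nitrogen, or a propyl chain on the sulfonyl, would be needed to tell these two changes apart.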